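A few compounds are considered here, and "the series" means these few. Any claim that something is new, unique, unknown or untested is made for them only; others in the source may bear on it.

Measured so far in an ADME assay on MT4 cells (Homo sapiens) for cytotoxicity, read by MTT assay, with a stated time of 5 days; a lower number here means that less compound is tolerated, a higher number that more compound is tolerated:
- compound 1, `O=C(CSc1snnc1-c1ccc(Br)cc1Br)Nc1ccccc1Cl`: > 240000 nM
- compound 2, `Cc1ccccc1NC(=O)CSc1snnc1-c1ccc(Br)cc1Br`: 202000 nM

The value of compound 1 in this assay is a limit of the assay, not a number; it sits at the limit of > 240000 nM in this assay, at which 1 of the 2 values shown sits. Going by the values given here, compound 2 gives the only number in the set, at 202000 nM. The step of an at least 1.1-fold lower number from compound 1 to compound 2 (0.07 log units; that floor lies within the scatter) has a floor within the usual scatter, so the two compounds cannot be ordered on these numbers.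

Compound 3 is `O=C(CSc1snnc1-c1ccc(Br)cc1Br)Nc1ccc(Cl)cc1`. It differs from compound 2 by 4-chlorophenyl in place of 2-methylphenyl on an amide-type nitrogen. Among the compounds with values here, the only measured step that bears on this change is the one from compound 1 to compound 2, which also exchanges a methyl and a chloro on the ring attached to the amide-type nitrogen, and that step stayed within the scatter. Within the data shown here, the present change moves the substituent to another position of the same ring, for which no measured step exists. No step beyond the scatter is therefore expected in this assay; the expected step is a 1.0-fold lower number from compound 2 to compound 3 (0.00 log units; within the scatter). Compound 3 is estimated at 200000 nM, within 90000 nM to 450000 nM, with a fair chance that only a limit is reported.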

Compound 3, half-maximal cytotoxic concentration: 23300 nM
For compound 3 the middle estimate is 8.6-fold (0.93 log units) above the measured one; measured number below the stated range.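

In this assay, the change to 4-chlorophenyl on the amide-type nitrogen gives the first step shown beyond the scatter: an 8.7-fold lower number from compound 2 to compound 3 (0.94 log units; beyond the scatter). With chloro kept on the ring and only 2-chlorophenyl exchanged for 4-chlorophenyl, the result is an at least 10-fold lower number from compound 1 to compound 3 (1.01 log units; beyond the scatter), so in this pair the place of the chloro on the ring alone separates the two compounds, whereas methyl in place of chloro gave a step that could not be ordered. The value of compound 1 is a limit of the assay and not a number, so this step is a floor and its true size stays unknown: the limit of > 240000 nM in this assay, at which 1 of the 3 values shown sits.

The compounds shown leave open whether the lower number goes with the 4-chlorophenyl group specifically or would also appear with a different group in the same place on the ring, such as 4-methylphenyl, and an unsubstituted phenyl on the same nitrogen would give the reference that is missing here. Also open, from the compounds shown here alone, is how far the tolerated concentration moves with a ring carrying an amine or a carboxylic acid, and whether any of this holds away from the shared core, which all three compounds keep.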